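Sulfonyl aryl variation on the quinolone core, antiproliferative notes

This account rests on a few compounds, and the source may have more. Where it says the series, first, only, none or still open, it means among the compounds named here.

Measured compounds:
- compound 1 `COC(=O)c1cc(=O)c2c(OC)cc(OC)cc2n1C` — > 37900 nM
- compound 2 `COC(=O)c1cc(=O)c2c(OC)cc(OC)cc2n1S(=O)(=O)c1ccc(C)cc1` — 139000 nM
- compound 3 `COc1ccc(-c2cc(=O)c3c(OC)cc(OC)cc3n2S(=O)(=O)c2cccc([N+](=O)[O-])c2)cc1` — > 39600 nM

In an ADME assay on BJ cells (Homo sapiens) for antiproliferative activity, with a stated time of 72 h (a higher number here means that more compound is needed for the effect, a lower number that less compound is needed), compound 1 reaches only a limit of the assay, > 37900 nM, as recorded under (the limit of > 37900 nM in this assay, at which 1 of the 3 values shown sits). Among the compounds with values here, compound 2 is the one member with a numerical read-out, giving 139000 nM in this assay. Compound 3 likewise reaches only a limit of the assay in this assay, > 39600 nM, as recorded under (the limit of > 39600 nM in this assay, at which 1 of the 3 values shown sits); it therefore stands at the weak end of the range seen, with no number to compare against compound 2.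

Compound 4 `COc1ccc(-c2cc(=O)c3c(OC)cc(OC)cc3n2S(=O)(=O)c2c(F)c(F)c(F)c(F)c2F)cc1` is not yet measured. It differs from compound 3 in one place: 2,3,4,5,6-pentafluorophenyl in place of 3-nitrophenyl on a sulfonyl sulfur. Within the data shown here, no measured pair isolates a change of this kind, so there is no step to lean on. Given that compound 3 sits at a limit, the expectation for compound 4 is again a read-out near or beyond the limit, with no shift beyond the scatter; the expected step is a step that the limit leaves unreadable from compound 3 to compound 4. The estimate for compound 4 in this assay is 60000 nM, within 20000 nM to 200000 nM.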

Compound 4, half-maximal effective concentration: > 34400 nM
Compound 4: a limit, no number (the forecaster's own chance of this, stated with the estimate: 70%); the middle value lies beyond the limit too.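

Compound 3 and compound 4 both stand at limits of this assay, not at numbers, and the step between them cannot be read. The compounds shown leave open how the aryl group on the sulfonyl sulfur bears on the read-out in this assay.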